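This account rests on a few compounds, and the source may have more. Where it says the series, first, only, none or still open, it means among the compounds named here.

Measured compounds and values in an assay on RAW264.7 cells for antagonist activity at Toll-like receptor 2 (Mus musculus), read by Griess assay, with a stated time of 24 h; a higher number here means a weaker inhibitor, a lower number a stronger inhibitor:
compound 1, `C#CCSC[C@H](N)C(=O)OC`: 94400 nM
compound 2, `COC(=O)[C@@H](N)CSCc1ccc(F)cc1`: 99600 nM
compound 3, `C=CCSC[C@H](NC(=O)c1cc(OC)c(OC)c(OC)c1)C(=O)OC`: 49300 nM

All three numbers lie in a narrow band. Compound 3 gives the lowest of the three; the number for compound 1 lies within the scatter of it, while the number for compound 2 lies beyond the scatter. Going by the values given here, no pair among the measured compounds differs in a single place, so no measured step is available.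

Compound 4, `C=CCCSC[C@H](NC(=O)c1cc(OC)c(OC)c(OC)c1)C(=O)OC`, differs from compound 3 by allyl in place of vinyl on a saturated chain carbon bound to a sulfur. The change adds one saturated chain carbon and nothing else; on the basis of the three measured compounds alone no step beyond the scatter is expected in this assay, in either direction. Compound 4 is therefore expected to give about 50000 nM, between 20000 nM and 125000 nM. The expected step of a 1.0-fold higher number from compound 3 to compound 4 (0.01 log units; within the scatter) stays within the usual scatter.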

Compound 4, half-maximal inhibitory concentration: 27300 nM
Estimate against measurement, compound 4: 1.8-fold (0.26 log units) above, and the stated range covers the measured number.
By their numbers in this assay, from the lowest: compounds 4, 3, 1 and 2 (each within the scatter of the next, the first and the last beyond it).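

In this assay, going by these compounds alone, allyl in place of vinyl on a saturated chain carbon bound to a sulfur gives a 1.8-fold lower number from compound 3 to compound 4 (0.26 log units; within the scatter) and provides the first single-place step. At this position, one added saturated chain carbon with the double bond retained therefore produces no step beyond the scatter.

Still open, as far as these compounds go, is whether a longer chain or a saturated butyl group at this position, or a carboxylic acid in place of the methyl ester, would move the number beyond the scatter. No supporting data bear on why the number for this pair falls where it does.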